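Ester to acid on a shared indole-free core? No—on the shared core

A few compounds are considered here, and "the series" means these few. Any claim that something is new, unique, unknown or untested is made for them only; others in the source may bear on it.

Measured compounds:
compound 1 `CCOC(=O)Nc1ccc(S(=O)(=O)n2c(C3(O)C=CC(=O)C=C3)cc3ccccc32)cc1` gives 190 nM
compound 2 `COC(=O)CCc1ccc(S(=O)(=O)n2c(C3(O)C=CC(=O)C=C3)cc3ccccc32)cc1` gives 680 nM
compound 3 `COC(=O)CCc1ccc(S(=O)(=O)n2c(C3(O)C=CC(=O)C=C3)cc3ccc(F)cc32)cc1` gives 500 nM

In a functional assay on NCI60 cells (Homo sapiens) for inhibition (a lower number here means a stronger inhibitor of growth, a higher number a weaker inhibitor of growth), compound 3 stands second highest of the three numbers. Compound 2 is nearest, with a step of a 1.4-fold lower number from compound 2 to compound 3 (0.13 log units; within the scatter), while compound 1 lies furthest, beyond the scatter. Within the data shown here, the only larger step among them is a 3.6-fold higher number from compound 1 to compound 2 (0.55 log units; beyond the scatter).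

Compound 4 `O=C1C=CC(O)(c2cc3ccc(F)cc3n2S(=O)(=O)c2ccc(CCC(=O)O)cc2)C=C1` differs from compound 3 by hydrogen in place of methyl on an oxygen next to a carbonyl group. Among the measured compounds shown here, neither measured step touches this oxygen, so no step here bears directly on the change, and the expectation rests on compound 3 alone. Compound 4 is therefore estimated near its parent, at 900 nM, within 250 nM to 4000 nM. The expected step is a 1.8-fold higher number from compound 3 to compound 4 (0.26 log units; within the scatter), not expected to exceed the scatter with confidence.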

Compound 4, concentration for 50% growth inhibition: 2500 nM
Compound 4: the middle estimate sits 2.8-fold (0.44 log units) below what was measured; measured number inside the range.
By their numbers in this assay, from the lowest: compound 1; then compounds 3 and 2 (each within the scatter of the next); then compound 4.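

In this assay, hydrogen in place of methyl on the oxygen next to a carbonyl group, which turns methoxycarbonyl into carboxy, gives a 5.0-fold higher number from compound 3 to compound 4 (0.70 log units; beyond the scatter). Among these compounds, this shows that the number responds to a change at this oxygen, a single heavy atom removed, whereas the fluoro step among the earlier compounds stayed within the scatter. Nothing shown explains the shift.

Going by these compounds, whether the step would hold on the shared core without fluoro remains open. So does how an amide or a longer ester at this position would read.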